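The source may report more compounds than this note shows. Statements on the series, on what has been measured and on what is new or still open speak of the compounds shown alone.

In an ADME assay on isolated protein for inhibition of Amine oxidase [flavin-containing] B (Homo sapiens) (on this read-out higher numbers stand for weaker inhibition and lower numbers for stronger inhibition), compound 1 `C#CCNC1CCc2c(SCc3cccc(OC)c3)cccc21` gives 1520 nM. Compound 2 `C#CCNC1CCc2c(SCCc3cccc(C)c3)cccc21` holds the highest of the two numbers: in this assay compound 2 gives 4960 nM, and the gap down to compound 1 lies beyond the usual scatter. Compound 3 `C#CCNC1CCc2c(SCCc3ccc(Cl)c(Cl)c3)cccc21` differs from compound 2 in one place: 3,4-dichlorophenyl in place of 3-methylphenyl on a saturated chain carbon, two bonds along the chain from a sulfur. Within the data shown here, no measured step of this kind is available, so the expected step, a 2.0-fold lower number from compound 2 to compound 3 (0.30 log units; within the scatter), is only a modest drop toward stronger inhibition, possibly within the scatter. Compound 3 is therefore expected to give about 2500 nM in this assay, within a range of 900 nM to 7000 nM.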

Compound 3, half-maximal inhibitory concentration: 2820 nM
Estimate against measurement, compound 3: 1.1-fold (0.05 log units) below, within the range that was stated.
By their numbers in this assay, from the lowest: compounds 1, 3 and 2 (each within the scatter of the next, the first and the last beyond it).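

Among these compounds, this is the first change at this position that can be read on its own. In this assay, 3,4-dichlorophenyl in place of 3-methylphenyl gives a 1.8-fold lower number from compound 2 to compound 3 (0.25 log units; within the scatter), so on a saturated chain carbon, two bonds along the chain from a sulfur, this change, which adds two chlorine atoms and removes a methyl group, leaves the read-out within the scatter. No supporting data bear on this result. From the compounds shown here alone, whether an unsubstituted phenyl, a pyridine ring or an amine at this place would move the number stays open. Steps involving compound 1 cannot be read, since it differs from compound 2 and compound 3 in more than one place.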